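Adding an Amino Group to Compound 3: Expected Cytotoxicity

A few compounds are considered here, and "the series" means these few. Any claim that something is new, unique, unknown or untested is made for them only; others in the source may bear on it.

Compound 1 `O=C(c1ccc(Cl)cc1)c1ccn(-c2ccc3c(c2)B(O)OC3)c1`: in an ADME assay on L929 cells (Mus musculus) for cytotoxicity, read by resazurin assay, with a stated time of 72 h (a higher number here means a weaker inhibitor, a lower number a stronger inhibitor), compound 1 gives > 10 ug/mL, a limit of the assay.
Compound 2 `O=C(c1ccc(O)cc1)c1ccn(-c2ccc3c(c2)B(O)OC3)c1`: in this assay compound 2 gives > 10 ug/mL, a limit.
Compound 3 `CCCC(=O)c1ccn(-c2ccc3c(c2)B(O)OC3)c1`: in this assay compound 3 gives > 10 ug/mL, a limit.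

Compound 3 therefore stands only at a limit in this assay, as do the two other measured compounds. The steps a step that the two limits leave unreadable from compound 1 to compound 2, a step that the two limits leave unreadable from compound 1 to compound 3 and a step that the two limits leave unreadable from compound 2 to compound 3 cannot be read, since (the limit of > 10 ug/mL in this assay, at which 3 of the 3 values shown sit). Compound 4 `NCCCC(=O)c1ccn(-c2ccc3c(c2)B(O)OC3)c1` differs from compound 3 by amino in place of hydrogen on a saturated chain carbon, three bonds along the chain from a carbonyl carbon. Going by the values given here, no measured step bears on this change, and no step size can be read from the three limits. Compound 4 is therefore expected to sit at or near the same limit in this assay, estimated at 15 ug/mL, between 6 ug/mL and 40 ug/mL. The expected step is a step that the limit leaves unreadable from compound 3 to compound 4, none beyond the scatter.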

Compound 4, half-maximal inhibitory concentration: > 10 ug/mL
Compound 4: no number, only a limit (the forecaster's own chance of this, stated with the estimate: 85%); the middle value is on the limit's open side.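

Compound 4 joins compound 1, compound 2 and compound 3 at a limit in this assay, so no step among these compounds can be read: the limit of > 10 ug/mL in this assay, at which 4 of the 4 values shown sit.

The compounds shown leave open whether any of the four differs from another in this assay.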